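Phenoxy in place of pyrrolidinyl on a series at the limit

The source may report more compounds than this note shows. Statements on the series, on what has been measured and on what is new or still open speak of the compounds shown alone.

Of the compounds shown here, two share a core, and neither yields a number so far. In a functional assay on NCI-H727 cells (Homo sapiens) for antiproliferative activity, with a stated time of 48 h (a lower number here means a stronger inhibitor, a higher number a weaker inhibitor), compound 1 `CN1CCN(c2ccc(-c3cccc(C(F)(F)F)c3)nn2)CC1` gives > 25000 nM, which is a limit of the assay. Compound 2 `FC(F)(F)c1cccc(-c2ccc(N3CCCC3)nn2)c1` gives > 25000 nM, which is also a limit. Among the compounds with values here, the one measured step, a step that the two limits leave unreadable from compound 1 to compound 2, therefore has no readable size. The evidence so far is the limit of > 25000 nM in this assay, at which 2 of the 2 values shown sit.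

The next change leads to compound 3 `FC(F)(F)c1cccc(-c2ccc(Oc3ccccc3)nn2)c1`, with phenoxy in place of pyrrolidin-1-yl on an aromatic carbon. The position is para to a large group, and the rest of the structure stays the same.

Within the data shown here, no measured step gives a size for this change, and no value shows what an aromatic group does at this position. With compound 2 only known as > 25000 nM, no clear step is expected in this assay, in either direction, and another limit is the most likely result. The expected step is a number no higher from compound 2 to compound 3 (the limit leaves the size open). For compound 3 the estimate is 25000 nM, with an expected range from 8000 nM to 60000 nM.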

Compound 3, half-maximal inhibitory concentration: > 25000 nM
Compound 3 gave a limit, no number; the forecaster's own chance of this, stated with the estimate: 65%; the middle value lies on the limit itself.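

In this assay compound 3 gives > 25000 nM, a limit of the assay and not a number. Within the data shown here, the steps among compound 1, compound 2 and compound 3 cannot be read, so no new step follows. The compounds shown leave open which change on the shared core, if any, would give a measurable value, as all readings stand at one limit: the limit of > 25000 nM in this assay, at which 3 of the 3 values shown sit.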